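From acetyl to a silicon-bearing group on compound 2

This account rests on a few compounds, and the source may have more. Where it says the series, first, only, none or still open, it means among the compounds named here.

Compound 2 (`COc1ccc(C2=C(c3cc(OC)c(OC)c(OC)c3)C(=O)C(OC(C)=O)C2)cc1`) gives < 1 ug/mL in an ADME assay on PA-1 cells (Homo sapiens) for cytotoxicity, read by MTT assay, with a stated time of 72 h (a lower number here means a stronger inhibitor, a higher number a weaker inhibitor), and this is a limit of the assay, not a number. Compound 1 (`COc1ccc(C2=C(c3cc(OC)c(OC)c(OC)c3)C(=O)C(OC(C)=O)C2)cc1OC(C)C`) gives > 100 ug/mL as a limit. Compound 3 (`COc1ccc(C2=C(c3cc(OC)c(OC)c(OC)c3)C(=O)C(OC(C)=O)C2)cc1F`) gives > 100 ug/mL as a limit as well. Compound 2 is thus the strongest inhibitor of the three and stands alone at the low end of the range.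

Compound 4 (`COc1ccc(C2=C(c3cc(OC)c(OC)c(OC)c3)C(=O)C(O[SiH2]C(C)(C)C)C2)cc1`) keeps the core of compound 2 and differs as follows: a group of 5 heavy atoms (4 carbon, 1 silicon; no ring) in place of a group of 3 heavy atoms (2 carbon, 1 oxygen; no ring), on an oxygen on a saturated carbon (a group of 5 heavy atoms in place of acetyl, on an oxygen on a saturated carbon).

Two measured steps are readable, both large and beyond the scatter: an at least 100-fold lower number from compound 1 to compound 2 (2.00 log units; beyond the scatter) and an at least 100-fold higher number from compound 2 to compound 3 (2.00 log units; beyond the scatter). Among the measured compounds shown here, both changes sit on an aromatic carbon, and no step at this oxygen has been measured, so they bear on the new change only indirectly. For the measured compounds named here, a rise is expected, with the size left wide, because an at least 100-fold higher number from compound 2 to compound 3 (2.00 log units; beyond the scatter) is the one measured change starting from compound 2 that gives a readable step. The expected shift is an at least 4.0-fold higher number from compound 2 to compound 4 (0.60 log units; beyond the scatter) in this assay as estimated here. Compound 4 is estimated at 4 ug/mL (expected range 0.3 ug/mL to 80 ug/mL).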

Compound 4, half-maximal inhibitory concentration: 7 ug/mL
Compound 4: middle estimate off by 1.8-fold (0.24 log units), on the low side; measured number inside the range.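

In this assay compound 2 gives < 1 ug/mL, which is a limit of the assay and not a number. Placing a group of 5 heavy atoms (4 carbon, 1 silicon) in place of acetyl, on an oxygen on a saturated carbon, gives an at least 7.0-fold higher number from compound 2 to compound 4 (0.84 log units; beyond the scatter); this is the first readable response at this oxygen, where the earlier steps all sat on an aromatic carbon, and compound 4 carries the first value in the series that is a number and not a limit. The true size of this step stays unknown, because its starting point is a limit: the limit of < 1 ug/mL in this assay, at which 1 of the 4 values shown sits.

The compounds shown hold no other group on this oxygen, such as a free hydroxyl, a methyl ether or a longer acyl chain, so it stays open whether the rise goes with the loss of acetyl or with the silicon-bearing group that enters. Also open is whether the isopropoxy and fluoro steps on the aromatic carbon would keep their direction with this group on the oxygen; it is shown only with hydrogen on that aromatic carbon.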